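This account rests on a few compounds, and the source may have more. Where it says the series, first, only, none or still open, it means among the compounds named here.

Compound 1 `COc1ccc(N2NC3=CC[C@@H](OC)O[C@@]3(c3ccccc3)CC2=O)cc1`: 10100 nM
Compound 2 `CO[C@@H]1CC=C2NN(c3ccc(Cl)cc3)C(=O)C[C@]2(C)O1`: 24200 nM
Compound 3 `CO[C@@H]1CC=C2NN(c3cc(Cl)cc(Cl)c3)C(=O)C[C@]2(c2ccncc2)O1`: 7600 nM

All three share one core and were tested in a functional assay on DU-145 cells (Homo sapiens) for inhibition, read by sulforhodamine B assay, with a stated time of 48 h; on this read-out higher numbers stand for weaker inhibition and lower numbers for stronger inhibition. Compound 1 gives 10100 nM. Compound 3 gives 7600 nM, a number within the usual scatter of that of compound 1. Compound 2 gives 24200 nM, a higher number beyond the scatter, so compound 2 inhibits less strongly than compound 1. Compound 4 `CO[C@@H]1CC=C2NN(c3cncnc3)C(=O)C[C@]2(c2ccccc2)O1` has not been measured. It differs from compound 1 in one place: pyrimidin-5-yl in place of 4-methoxyphenyl on an amide-type nitrogen in a ring. Within the data shown here, no measured pair shows this exact change, so its effect is unknown; a step not far beyond the scatter, towards a higher number, is expected. Compound 4 is expected to give 15000 nM, between 5000 nM and 45000 nM. The expected step is a 1.5-fold higher number from compound 1 to compound 4 (0.17 log units; within the scatter).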

Compound 4, half-maximal inhibitory concentration: 7330 nM
Compound 4: middle estimate off by 2.0-fold (0.31 log units), on the high side; low and high end bracket the measured number.
By their numbers in this assay, from the lowest: compounds 4, 3 and 1 (each within the scatter of the next); then compound 2.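

In this assay, placing pyrimidin-5-yl where 4-methoxyphenyl stood on the amide-type nitrogen gives a 1.4-fold lower number from compound 1 to compound 4 (0.14 log units; within the scatter) and so no change that stands clear of the scatter. Among these compounds, this position therefore accepts a smaller aromatic ring with 2 hetero atoms about as well as a carbon-only one bearing a methoxy group. No measurement here explains why the two groups read alike.

Still open, as far as these compounds go, is whether an aromatic ring is needed here at all, as a plain butyl chain or a piperidine ring would show. Also open, from the compounds shown here alone, is whether pyrimidin-5-yl behaves the same with a pyridin-4-yl group in place of the phenyl group.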